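A few compounds are considered here, and "the series" means these few. Any claim that something is new, unique, unknown or untested is made for them only; others in the source may bear on it.

Measured so far:
compound 1, `ClCc1cccc(Cn2cnc3c(Cl)nc(Cl)nc32)c1`: > 100000 nM
compound 2, `ClCc1cccc(Cn2cnc3nc(Cl)nc(Cl)c32)c1`: 2750 nM
compound 3, `ClCc1ccc(Cn2cnc3nc(Cl)nc(Cl)c32)cc1`: 31600 nM

In a functional assay on CCRF-CEM cells (Homo sapiens) for cytotoxicity, read by sulforhodamine B assay, with a stated time of 48 h (on this read-out higher numbers stand for weaker inhibition of growth and lower numbers for stronger inhibition of growth), compound 1 gives > 100000 nM, which is a limit of the assay rather than a number. Within the data shown here, it is the only one of the three readings that sits there (the limit of > 100000 nM in this assay, at which 1 of the 3 values shown sits). Compound 2 gives 2750 nM in this assay. Compound 3 gives 31600 nM in this assay. No pair among these three differs in a single place, so their values are set side by side without a computed step between them; compound 1 stands where the assay stops reporting a number.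

Compound 4 `ClCc1cccc(Cn2cnc3c(Cl)ncnc32)c1` differs from compound 1 by hydrogen in place of chloro on an aromatic carbon. The remainder of the structure is unchanged. Among the measured compounds shown here, no measured pair shows what the loss of one chloro from this core does in this assay, so the size of the step cannot be read from the data. The expectation is that compound 4 stays near compound 1, with a step that the limit leaves unreadable from compound 1 to compound 4 that is not beyond the usual scatter, and that the assay may again report only a limit. Compound 4 is estimated at 120000 nM, with a range from 25000 nM to 400000 nM.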

Compound 4, concentration for total growth inhibition: 3890 nM
Estimate against measurement, compound 4: 31-fold (1.49 log units) above; measured number below the stated range.
By their numbers in this assay, from the lowest: compounds 2 and 4 (each within the scatter of the next); then compound 3. At a limit, above all of these: compound 1.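

In this assay compound 1 gives > 100000 nM, which is a limit of the assay and not a number. Hydrogen in place of chloro on the aromatic carbon between two ring nitrogen atoms gives an at least 25-fold lower number from compound 1 to compound 4 (1.41 log units; beyond the scatter), the first change in a single place in this series, and it shows that this one position alone can separate a reading at the limit from a measured number for inhibition of growth. The step gives a minimum and not a full size, since one end of it is a limit: the limit of > 100000 nM in this assay, at which 1 of the 4 values shown sits.

Still open, going by these compounds, is whether another group on the same carbon, such as an amine or a methoxy group, would read like hydrogen or like chloro, and how far the number would move with each. Also open, on these data alone, are whether the same exchange of chloro for hydrogen has a comparable effect on the core of compound 2 or compound 3, and what the remaining chloro on compound 4 contributes to its reading.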